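Stripping the Alkyl Chain in a 5-Lipoxygenase Series

The source may hold more compounds than are shown below. What is called first, only, known or untested is meant among the compounds shown, and "the series" means these compounds.

Compound 1 `CC(C)CC(C#Cc1cccc(C(=O)NCc2ccccc2C(F)(F)F)c1)N(O)C(N)=O` — 600 nM
Compound 2 `CCCC(C#Cc1cccc(C(=O)NCc2ccccc2C(F)(F)F)c1)N(O)C(N)=O` — 300 nM

Within the data shown here, in an assay for inhibition of Polyunsaturated fatty acid 5-lipoxygenase (Homo sapiens), read by HPLC, with stated times of 15 min and 10 min (on this read-out higher numbers stand for weaker inhibition and lower numbers for stronger inhibition), compound 2 carries the lowest of the two numbers so far; its only neighbour is compound 1, which sits a step of a 2.0-fold lower number from compound 1 to compound 2 (0.30 log units; within the scatter) away, within the scatter. Compound 3 `NC(=O)N(O)CC#Cc1cccc(C(=O)NCc2ccccc2C(F)(F)F)c1` differs from compound 2 by hydrogen in place of propyl on a saturated chain carbon bound to an amide-type nitrogen and a triple-bonded carbon. Among the measured compounds shown here, the one measured step that bears on this change is the one from compound 1 to compound 2, where a single methyl was taken off the same chain region and the number moved only within the scatter. For the measured compounds named here, the present change is larger, removing three carbons rather than one, and no measured compound lacks the chain altogether, so the expectation rests on thin ground. A modest rise in the number is expected, as the step of a 2.7-fold higher number from compound 2 to compound 3 (0.43 log units; beyond the scatter). Compound 3 is therefore estimated at 800 nM, with a range from 250 nM to 3000 nM.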

Compound 3, half-maximal inhibitory concentration: 4000 nM
Estimate against measurement, compound 3: 5.0-fold (0.70 log units) below, and the stated range ends below it.
By their numbers in this assay, from the lowest: compounds 2 and 1 (each within the scatter of the next); then compound 3.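

In this assay the group on the saturated chain carbon bound to an amide-type nitrogen and a triple-bonded carbon proves to matter: hydrogen in place of propyl gives a 13-fold higher number from compound 2 to compound 3 (1.12 log units; beyond the scatter) and hydrogen in place of isobutyl gives a 6.7-fold higher number from compound 1 to compound 3 (0.82 log units; beyond the scatter). The earlier pair showed only that propyl and isobutyl read alike within the scatter, whereas losing the chain altogether moves the number beyond the scatter from either of them. Nothing available explains this rise in the number.

The compounds shown leave open how small the chain can become before the number rises, as a methyl or an ethyl in this place would show. They also leave open whether a longer chain, such as hexyl, or a cyclopropyl would read like propyl and isobutyl.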